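Swapping Phenyl for Phenoxymethyl on the Outer Ring

The source may hold more compounds than are shown below. What is called first, only, known or untested is meant among the compounds shown, and "the series" means these compounds.

Compound 3 `CN(C)C(=O)c1cnc(C(=O)CCc2ccc(-c3ccccc3)cc2)o1` carries a phenyl on its outer aromatic ring, and in an assay for inhibition of Fatty-acid amide hydrolase 1 (Rattus norvegicus) (a higher number here means a weaker inhibitor, a lower number a stronger inhibitor), compound 3 gives 3 nM. Among the three numbers known it sits in the middle: compound 1 `CN(C)C(=O)c1cnc(C(=O)CCc2ccc(Oc3ccccc3)cc2)o1` gives 5.4 nM and compound 2 `COC(=O)c1cnc(C(=O)CCc2ccc(COc3ccccc3)cc2)o1` gives 1.6 nM, each within the scatter of compound 3. Compound 4 `CN(C)C(=O)c1cnc(C(=O)CCc2ccc(COc3ccccc3)cc2)o1` is compound 3 with phenoxymethyl in place of phenyl on an aromatic carbon. Going by the values given here, no measured step matches this exact change. Among the compounds with values here, the one measured step, a 1.8-fold lower number from compound 1 to compound 3 (0.26 log units; within the scatter), stayed within the scatter, and compound 2, which already carries phenoxymethyl, shows a number close to that of compound 3. The change is therefore expected to give no step beyond the scatter, a 1.2-fold lower number from compound 3 to compound 4 (0.08 log units; within the scatter). Compound 4 is estimated at 2.5 nM, with a range from 1 nM to 6 nM.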

Compound 4, inhibition constant: 6.7 nM
Beside the measured number, compound 4's estimate is 2.7-fold (0.43 log units) below it; the measured number lies above the stated range.
By their numbers in this assay, from the lowest: compounds 2, 3, 1 and 4 (each within the scatter of the next, the first and the last beyond it).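

In this assay, the outer ring's substituent now makes a visible difference: a 2.2-fold higher number from compound 3 to compound 4 (0.35 log units; beyond the scatter) is a modest step beyond the scatter, whereas a 1.2-fold higher number from compound 1 to compound 4 (0.09 log units; within the scatter) stays within it. The group on the other carbonyl also counts, since dimethylamino in place of methoxy gives a 4.2-fold higher number from compound 2 to compound 4 (0.62 log units; beyond the scatter) and is a modest step beyond the scatter. No evidence at hand accounts for these steps.

Open, on these data alone, is whether the dimethylamino step would persist with phenyl or phenoxy on the outer ring. Also open, as far as these compounds go, is how an amine or a carboxylic acid would fare at that outer-ring position.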